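The source may hold more compounds than are shown below. What is called first, only, known or untested is meant among the compounds shown, and "the series" means these compounds.

Measured in an ADME assay on microsomes from liver (Homo sapiens) for metabolic stability; a lower number here means slower removal, a higher number faster removal of the compound:
- Compound 1 `CCn1cnc2c(-c3ccc(F)c(-c4cccnc4)c3)cnnc21`: 78 mL.min-1.g-1
- Compound 2 `CCn1cnc2c(-c3ccc(F)c(Oc4ccnc(C)c4)c3)cnnc21`: 65 mL.min-1.g-1
- Compound 3 `CCn1cnc2c(-c3ccnc(Oc4cccc(S(=O)(=O)CC)c4)c3)cnnc21`: < 8 mL.min-1.g-1, a limit of the assay

The two numeric values in this assay lie within the scatter of each other, with a 1.2-fold lower number from compound 1 to compound 2 (0.08 log units; within the scatter). Going by the values given here, compound 2 therefore stands level with the only other compound that has a number. The remaining entry is the limit of < 8 mL.min-1.g-1 in this assay, at which 1 of the 3 values shown sits.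

Compound 4 `CCn1cnc2c(-c3ccc(F)c(Oc4cnc(C#N)nc4)c3)cnnc21` is not yet measured. The change is 2-cyanopyrimidin-5-yl in place of 2-methylpyridin-4-yl on an oxygen on an aromatic ring, with 2-cyanopyrimidin-5-yl in place of 2-methylpyridin-4-yl on an oxygen on an aromatic ring.

Among the compounds with values here, no measured step covers this exchange. Within the data shown here, the one available step, a 1.2-fold lower number from compound 1 to compound 2 (0.08 log units; within the scatter), is a different exchange and sets no size. Among the measured compounds shown here, the only pointer towards lower numbers is compound 3, whose < 8 mL.min-1.g-1 is a limit, and no single-place step links it to compound 2. A moderate move towards slower removal is therefore expected, with low confidence.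

The expected change is a 2.2-fold lower number from compound 2 to compound 4 (0.34 log units; beyond the scatter). For compound 4 the estimate is 30 mL.min-1.g-1, with an expected range of 10 mL.min-1.g-1 to 70 mL.min-1.g-1.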

Compound 4, intrinsic clearance in microsomes: 49 mL.min-1.g-1
Compound 4: the middle estimate sits 1.6-fold (0.21 log units) below what was measured; the range from low to high includes it.
By their numbers in this assay, from the lowest: compounds 4, 2 and 1 (each within the scatter of the next). At a limit, below all of these: compound 3.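

At this place, on an oxygen on an aromatic ring, 2-cyanopyrimidin-5-yl reads level with 2-methylpyridin-4-yl in this assay, with a 1.3-fold lower number from compound 2 to compound 4 (0.12 log units; within the scatter) and no separation between the two groups. Against the pyridin-3-yl on an aromatic carbon of compound 1, a 1.6-fold lower number from compound 1 to compound 4 (0.20 log units; within the scatter) and so compound 1, compound 2 and compound 4 form one level in this assay, even with a second ring hetero atom and a triple bond outside aromatic rings in the entering group. Nothing measured here accounts for this level.

Going by these compounds alone, compound 3 gives < 8 mL.min-1.g-1 as a limit, and no single-place step ties it to the others. Open, from the compounds shown here alone, is whether an amine or a carboxylic acid on the ring carried by the oxygen would give a step beyond the scatter from compound 2.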